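Series notes: oxazole to methylhydantoin at the benzylic position

The compounds below may be only part of what the source reports. "The series", "measured", "known", "first", "only" and "open" are said of these compounds alone.

The shared core carries a butyl carbamate sulfonyl group on the thiophene ring bearing an isobutyl chain, and a benzyl-linked heterocycle that varies. Compound 1 `CCCCOC(=O)NS(=O)(=O)c1sc(CC(C)C)cc1-c1ccc(Cn2cnc(C(F)(F)F)c2)cc1` gives 7.3 nM in an assay on membranes from uterus for displacement of a labelled ligand from Angiotensin type II receptor (Sus scrofa), with a stated time of 1.5 h; on this read-out lower numbers stand for stronger inhibition and higher numbers for weaker inhibition. Compound 2 `CCCCOC(=O)NS(=O)(=O)c1sc(CC(C)C)cc1-c1ccc(Cc2ncco2)cc1` gives 3.9 nM in this assay. Going by the values given here, the only step measured so far, a 1.9-fold lower number from compound 1 to compound 2 (0.27 log units; within the scatter), is within the scatter, so compound 2 and compound 1 stand as one level; compound 2 holds the smaller of the two numbers by a margin that means nothing on its own. Compound 3 `CCCCOC(=O)NS(=O)(=O)c1sc(CC(C)C)cc1-c1ccc(CN2C(=O)CN(C)C2=O)cc1` differs from compound 2 by 3-methyl-2,5-dioxoimidazolidin-1-yl in place of 1,3-oxazol-2-yl on a saturated chain carbon bound to an aromatic carbon. Among the compounds with values here, no measured step bears directly on this change: the one step available swaps one five-membered aromatic ring for another and stayed within the scatter, and no non-aromatic ring has been tried at this position. A step of about a 1.5-fold higher number from compound 2 to compound 3 (0.19 log units; within the scatter) is therefore expected, essentially none beyond the scatter, with wide uncertainty. Compound 3 is estimated at 6 nM, with a range from 2 nM to 20 nM.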

Compound 3, inhibition constant: 68.6 nM
Compound 3: middle estimate off by 11-fold (1.06 log units), on the low side, outside the stated range (above it).
By their numbers in this assay, from the lowest: compounds 2 and 1 (each within the scatter of the next); then compound 3.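

In this assay the group on the saturated chain carbon bound to an aromatic carbon is not freely exchangeable: 3-methyl-2,5-dioxoimidazolidin-1-yl gives an 18-fold higher number from compound 2 to compound 3 (1.25 log units; beyond the scatter) and also a 9.4-fold higher number from compound 1 to compound 3 (0.97 log units; beyond the scatter) and both steps lie beyond the scatter. The two five-membered aromatic rings stand as one level, and the five-membered non-aromatic ring stands apart from both, so a five-membered ring as such does not secure the level of compound 1 and compound 2. Nothing measured here accounts for this step.

With a single non-aromatic ring, the effects of losing aromaticity, of the carbonyl groups and of the methyl group on that ring cannot be told apart. From the compounds shown here alone, what a simple amine or a carboxylic acid on this same chain carbon would give remains open.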